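Ester variation and paw edema inhibition

The compounds below may be only part of what the source reports. "The series", "measured", "known", "first", "only" and "open" are said of these compounds alone.

Three esters share one core. In a functional assay on the whole organism (strain Sprague-Dawley CD) for inhibition, with Rattus norvegicus as the target, read by paw edema, at a dose of 30 mg/kg by the oral route (a lower number here means a weaker effect, a higher number a stronger effect of the compound at the dose given), compound 1 `CCOC(=O)C(=O)Nc1cccccc1=O` gives 79%, compound 2 `CC(C)OC(=O)C(=O)Nc1cccccc1=O` gives 63%, and compound 3 `CC(C)(C)OC(=O)C(=O)Nc1cccccc1=O` gives 47%, the lowest of the three numbers. The measured steps all run downward: a number 16 percentage points lower from compound 1 to compound 2 (beyond the scatter) and a number 16 percentage points lower from compound 2 to compound 3 (beyond the scatter), which together make a number 32 percentage points lower from compound 1 to compound 3 (beyond the scatter). Compound 4 `CCCCCOC(=O)C(=O)Nc1cccccc1=O` has not yet been measured in this assay. It differs from compound 3 as follows: pentyl in place of tert-butyl on an oxygen next to a carbonyl group. Going by the values given here, no measured step covers a straight chain longer than ethyl, so the bearing of the steps is indirect: each methyl placed on a saturated chain carbon bound to an oxygen next to a carbonyl group lowered inhibition, and pentyl removes that branching while adding chain length. For compound 4 the step is therefore expected to be a number 15 percentage points higher from compound 3 to compound 4 (beyond the scatter), an upward move that stops short of the number seen for compound 1. Compound 4 is thus expected to give about 62% in this assay, within 42% to 80%.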

Compound 4, a percentage reported as inhibition, in the whole organism at one dose (the size of the read-out at that dose, not a potency): 12%
The estimate for compound 4 lay 50 percentage points above the measured number, and the stated range ends above it.
By their numbers in this assay, from the lowest: compound 4; then compound 3; then compound 2; then compound 1.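

Going from the branched groups to pentyl on an oxygen next to a carbonyl group does not recover inhibition in this assay but lowers it further, with a number 35 percentage points lower from compound 3 to compound 4 (beyond the scatter) and a number 51 percentage points lower from compound 2 to compound 4 (beyond the scatter) and, against the ethyl ester, a number 67 percentage points lower from compound 1 to compound 4 (beyond the scatter) as the largest step in the series. Going by these compounds alone, the order of the four esters now follows the carbon count of the group, from ethyl through isopropyl and tert-butyl to pentyl, with no compound against it, so branching alone no longer describes the trend at this position. Nothing on hand explains this fall.

Going by these compounds, what a straight propyl or butyl ester gives remains open, so the point between ethyl and pentyl at which inhibition drops is unknown. Also open, on these data alone, is whether a methyl ester, or a pentyl chain ending in an amine or a carboxylic acid, would keep inhibition at this dose.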